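A few compounds are considered here, and "the series" means these few. Any claim that something is new, unique, unknown or untested is made for them only; others in the source may bear on it.

Measured so far:
- compound 1 `C=CC(=O)N1C(=O)CC(c2ccc(C(F)(F)F)cc2)Sc2ccccc21`: 47600 nM
- compound 2 `C=CC(=O)N1C(=O)CC(c2ccc(Cl)cc2)Sc2ccccc21`: 18400 nM

In a functional assay on Raji cells (Homo sapiens) for cytotoxicity, read by CCK-8 assay, with a stated time of 24 h (on this read-out higher numbers stand for weaker inhibition and lower numbers for stronger inhibition), compound 2 gives the lower of the two numbers, 18400 nM. Compound 3 `C=CC(=O)N1C(=O)CC(c2ccc(-c3ccccc3)cc2)Sc2ccccc21` has not yet been measured. It differs from compound 2 as follows: phenyl in place of chloro on an aromatic carbon. In short, it has phenyl in place of chloro on an aromatic carbon.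

Going by the values given here, only one measured step bears on this change: a 2.6-fold lower number from compound 1 to compound 2 (0.41 log units; beyond the scatter). That swap, chloro in place of trifluoromethyl, was modest. A single step cannot fix a direction for phenyl, so only a small move is expected, leaning towards a higher number. The expected step is a 1.6-fold higher number from compound 2 to compound 3 (0.21 log units; within the scatter). The estimated value for compound 3 is 30000 nM, with an expected range from 9000 nM to 90000 nM.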

Compound 3, half-maximal inhibitory concentration: 56300 nM
Estimate against measurement, compound 3: 1.9-fold (0.27 log units) below, and the stated range covers the measured number.
By their numbers in this assay, from the lowest: compound 2; then compounds 1 and 3 (each within the scatter of the next).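

At this place on the aromatic ring, the new result shows that chloro stands apart from both other groups in this assay: swapping it for phenyl gives a 3.1-fold higher number from compound 2 to compound 3 (0.49 log units; beyond the scatter) and moves the number back up. Phenyl and trifluoromethyl cannot be told apart, with a 1.2-fold higher number from compound 1 to compound 3 (0.07 log units; within the scatter) as the step between them, even though phenyl brings 6 heavy atoms and an extra ring. No measurement shown explains these differences. On these data alone, whether an amine, a carboxylic acid or a methoxy group here would give a lower number than chloro remains open.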